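This account rests on a few compounds, and the source may have more. Where it says the series, first, only, none or still open, it means among the compounds named here.

In a functional assay on SF-295 cells (Homo sapiens) for antiproliferative activity, read by sulforhodamine B assay, with a stated time of 72 h (a lower number here means a stronger inhibitor, a higher number a weaker inhibitor), compound 1 `Cc1cc(C)nc(NS(=O)(=O)c2ccc(Nc3nncc4ccccc34)cc2)n1` gives 0.56 nM, and compound 2 `O=S(=O)(Nc1ncccn1)c1ccc(Nc2nncc3ccccc23)cc1` gives 7.6 nM. Compound 2 thus holds the higher of the two numbers, which makes it the weaker inhibitor of this pair. Compound 3 `O=S(=O)(Nc1nccs1)c1ccc(Nc2nncc3ccccc23)cc1` keeps the shared core and alters one group: 1,3-thiazol-2-yl in place of pyrimidin-2-yl on a sulfonamide nitrogen. In plain words, 1,3-thiazol-2-yl stands in place of pyrimidin-2-yl on a sulfonamide nitrogen, so a five-membered aromatic ring replaces a six-membered one.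

Among the compounds with values here, only one measured step bears on this change: a 14-fold higher number from compound 1 to compound 2 (1.13 log units; beyond the scatter). That large step, with pyrimidin-2-yl in place of 4,6-dimethylpyrimidin-2-yl, shows that a change on this same nitrogen can move the number well beyond the scatter. It involved a different pair of groups, however, so it gives no direction for the new swap. A sizeable move either way remains possible, but the best guess stays close to the starting value. The expected change is a 1.3-fold lower number from compound 2 to compound 3 (0.10 log units; within the scatter), and that central guess carries no firm direction. For compound 3 the estimated value is 6 nM, with an expected range from 1.2 nM to 30 nM.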

Compound 3, half-maximal inhibitory concentration: 6.5 nM
Compound 3: the middle estimate sits 1.1-fold (0.03 log units) below what was measured; the measured number falls inside the stated range.
By their numbers in this assay, from the lowest: compound 1; then compounds 3 and 2 (each within the scatter of the next).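

In this assay, replacing the six-membered pyrimidin-2-yl ring with the five-membered 1,3-thiazol-2-yl ring on the sulfonamide nitrogen gives a 1.2-fold lower number from compound 2 to compound 3 (0.07 log units; within the scatter), so the two groups cannot be told apart here despite their different ring sizes. This shows that not every change on this nitrogen moves the number beyond the scatter, which the earlier large step alone could not show. The gap to the 4,6-dimethylpyrimidin-2-yl group of compound 1 also remains with the new ring, at a 12-fold higher number from compound 1 to compound 3 (1.06 log units; beyond the scatter), so among these three compounds that group alone stands apart, and no measurement here explains why the two unmethylated rings match or why compound 1 differs.

On these data alone, it remains open whether the gap to compound 1 needs both methyl groups, or whether methyl groups on the 1,3-thiazol-2-yl ring would bring the number down in the same way. Also open, as far as these compounds go, is where a phenyl ring or an acetyl group on this nitrogen would fall.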